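This account rests on a few compounds, and the source may have more. Where it says the series, first, only, none or still open, it means among the compounds named here.

Measured in a functional assay on A549 cells (Homo sapiens) for cytotoxicity; on this read-out lower numbers stand for an effect already at smaller amounts and higher numbers for an effect only at larger amounts of compound:
- compound 1 `CCOc1cc(-c2ccccc2)nc2ccccc12`: > 10 ug/mL, a limit of the assay
- compound 2 `Oc1ccc2c(O)cc(-c3ccccc3)nc2c1`: 0.81 ug/mL

In this assay, compound 2 stands alone with a true number, 0.81 ug/mL, so it has no measured neighbour to be ranked against. Compound 3 `Oc1cc(-c2ccccc2)nc2cc(F)ccc12` differs from it by fluoro in place of hydroxy on an aromatic carbon. Among the measured compounds shown here, no measured step covers this change, so any forecast is tentative. The expected change is a 4.9-fold higher number from compound 2 to compound 3 (0.69 log units; beyond the scatter), a move toward an effect only at larger amounts, beyond the usual scatter. For compound 3 the estimated value is 4 ug/mL, with an expected range of 1 ug/mL to 15 ug/mL.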

Compound 3, half-maximal effective concentration: 0.96 ug/mL
For compound 3 the middle estimate is 4.2-fold (0.62 log units) above the measured one, and the stated range ends above it.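

In this assay, putting fluoro in place of hydroxy on this aromatic carbon, meta to a fused ring and para to a fused ring, gives a 1.2-fold higher number from compound 2 to compound 3 (0.07 log units; within the scatter). The read-out at this place therefore stays within the scatter with an entering group that has 0 hydrogen-bond donors and 0 hydrogen-bond acceptors, which compound 2 alone could not show. Nothing measured here gives a cause for this step. As far as these compounds go, how an amine, a methoxy group or a longer chain would read at this place remains open.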